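Amide variation on the shared core

The source may report more compounds than this note shows. Statements on the series, on what has been measured and on what is new or still open speak of the compounds shown alone.

The series keeps the core of compound 1 `CCN(CC)S(=O)(=O)c1ccc(S(=O)(=O)N2CCC[C@@H](C(=O)N(C)C(C)C)C2)cc1` and varies only the group on the carbonyl carbon. In a functional assay on MIA PaCa-2 cells (Homo sapiens) for inhibition, read by MTT assay, with a stated time of 3 days (on this read-out lower numbers stand for stronger inhibition and higher numbers for weaker inhibition), compound 1 gives only a limit of the assay, > 10000 nM. Compound 2 `CCN(CC)S(=O)(=O)c1ccc(S(=O)(=O)N2CCC[C@@H](C(=O)N3CCN(c4nc(C(F)(F)F)no4)CC3)C2)cc1`, carrying a larger amide substituent, also returns only a limit in this assay, > 10000 nM. Within the data shown here, the whole picture so far is the limit of > 10000 nM in this assay, at which 2 of the 2 values shown sit, so compound 1 stands at that limit and nowhere else on the numbers, and no measured step between two compounds exists.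

Compound 3 `CCN1CC(NC(=O)[C@@H]2CCCN(S(=O)(=O)c3ccc(S(=O)(=O)N(CC)CC)cc3)C2)C1` is still to be measured in this assay. It differs from compound 1 by (1-ethylazetidin-3-yl)amino in place of isopropyl(methyl)amino on a carbonyl carbon, in words (1-ethylazetidin-3-yl)amino in place of isopropyl(methyl)amino on a carbonyl carbon. With every known value sitting at the limit of > 10000 nM in this assay, at which 2 of the 2 values shown sit, the data give no step size and no direction for a change at this position. The expected step of a number no higher from compound 1 to compound 3 (the limit leaves the size open) is therefore none beyond the scatter, with a limit again the most likely outcome. Compound 3 is estimated at 10000 nM, in the range 3000 nM to 30000 nM.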

Compound 3, half-maximal inhibitory concentration: > 10000 nM
Compound 3 was reported as a limit (the forecaster's own chance of this, stated with the estimate: 80%); the middle value lies on the limit itself.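

In this assay compound 3 gives > 10000 nM as a limit of the assay. No step can be read between compound 1 and compound 3, and the series still offers no measured difference: the limit of > 10000 nM in this assay, at which 3 of the 3 values shown sit. The compounds shown leave open whether any amide group on the shared core gives a measurable value in this assay in this series.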